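Imidazolylbutyl in place of pyrrolylpropyl on the pyrazolopyridine nitrogen

The source may hold more compounds than are shown below. What is called first, only, known or untested is meant among the compounds shown, and "the series" means these compounds.

Measured so far:
compound 1, `Cn1cc(C2=C(c3n[nH]c4ncccc34)C(=O)N(c3cccc4ccccc34)C2=O)c2ccccc21`: in a functional assay on KB cells (Homo sapiens) for antiproliferative activity, read by MTT assay, with a stated time of 48 h (on this read-out lower numbers stand for stronger inhibition and higher numbers for weaker inhibition), compound 1 gives > 100000 nM, a limit of the assay and not a number.
compound 2, `Cn1cc(C2=C(c3nn(CCCn4cccc4)c4ncccc34)C(=O)N(c3ccccc3)C2=O)c2ccccc21`: in this assay compound 2 gives > 100000 nM, again a limit.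
compound 3, `Cn1cc(C2=C(c3nn(CCCN4CCCCC4)c4ncccc34)C(=O)N(c3ccc(Cl)cc3)C2=O)c2ccccc21`: in this assay compound 3 gives > 100000 nM, also a limit.

Compound 2 therefore stands exactly where the whole measured set stands: the limit of > 100000 nM in this assay, at which 3 of the 3 values shown sit. Within the data shown here, no measured compound differs from another in a single place, so no measured step exists to calibrate against, and the series supplies no number at all, only limits.

Compound 4, `Cn1cc(C2=C(c3nn(CCCCn4ccnc4)c4ncccc34)C(=O)N(c3ccccc3)C2=O)c2ccccc21`, is the next variant of compound 2. The difference is (1H-imidazol-1-yl)methyl in place of 1H-pyrrol-1-yl on a saturated chain carbon, three bonds along the chain from an aromatic nitrogen.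

Among the measured compounds shown here, with every measured value a limit and no step to lean on, the expectation for this change is no step beyond the usual scatter; the step of a number no higher from compound 2 to compound 4 (the limit leaves the size open) is expected to be essentially nil. Compound 4 is accordingly expected to come out near 100000 nM, within 30000 nM to 300000 nM, and most probably to be reported as a limit once more.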

Compound 4, half-maximal inhibitory concentration: 47300 nM
Beside the measured number, compound 4's estimate is 2.1-fold (0.33 log units) above it, within the range that was stated.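

In this assay, 4-(1H-imidazol-1-yl)butyl in place of 3-(1H-pyrrol-1-yl)propyl on the aromatic nitrogen gives an at least 2.1-fold lower number from compound 2 to compound 4 (0.32 log units; beyond the scatter). Among these compounds, this is the first sign that the series responds to a change at this position, although the size of the step stays open, with only a lower bound on it. The 4-(1H-imidazol-1-yl)butyl chain alone gives a number here, while the rest of the set stays at a limit: the limit of > 100000 nM in this assay, at which 3 of the 4 values shown sit.

The change lengthens the chain and swaps the ring in a single move, so the compounds shown do not tell the two apart; 3-(1H-imidazol-1-yl)propyl and 4-(1H-pyrrol-1-yl)butyl would separate them. On these data alone, whether a longer chain, such as 5-(1H-imidazol-1-yl)pentyl, moves the number further also remains open.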